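Adding a bromo to the phenyl of compound 1

The source may report more compounds than this note shows. Statements on the series, on what has been measured and on what is new or still open speak of the compounds shown alone.

Values in a functional assay on WM 266-4 cells (Homo sapiens) for antiproliferative activity, read by MTT assay, with a stated time of 48 h; on this read-out higher numbers stand for weaker inhibition and lower numbers for stronger inhibition:

- Compound 1 `O=C(Nc1cc(-c2ccccc2)[nH]n1)c1cccnc1F` gives 3770 nM
- Compound 2 `O=C(Nc1cc(-c2ccccc2)[nH]n1)c1cncc(Br)c1` gives 6880 nM
- Compound 3 `O=C(Nc1cc(-c2ccccc2)[nH]n1)c1ccc(Cl)nc1` gives 6430 nM

Compound 1 cannot be separated from the other two on these numbers. The data show a 1.8-fold higher number from compound 1 to compound 2 (0.26 log units; within the scatter) and a 1.7-fold higher number from compound 1 to compound 3 (0.23 log units; within the scatter), and the remaining pair shows a 1.1-fold lower number from compound 2 to compound 3 (0.03 log units; within the scatter).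

Compound 4 `O=C(Nc1cc(-c2ccc(Br)cc2)[nH]n1)c1cccnc1F` is compound 1 with one change, phenyl to 4-bromophenyl: bromo in place of hydrogen on an aromatic carbon. In words, this is bromo in place of hydrogen on an aromatic carbon.

Among the measured compounds shown here, none of the measured steps touches this phenyl. All three exchange the pyridinyl group on the carbonyl carbon, so they bear on the new change only indirectly. They show that halogen swaps elsewhere on the shared core stayed within the scatter, and they give no direction for a bromo on the phenyl. The expectation in this assay is therefore no step beyond the scatter, with wide uncertainty in either direction.

The expected step is a 1.1-fold lower number from compound 1 to compound 4 (0.03 log units; within the scatter).

For compound 4 the estimated value is 3500 nM, with an expected range from 1200 nM to 10000 nM.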

Compound 4, half-maximal inhibitory concentration: 4680 nM
Compound 4: the middle estimate sits 1.3-fold (0.13 log units) below what was measured; measured number inside the range.
By their numbers in this assay, from the lowest: compounds 1, 4, 3 and 2 (each within the scatter of the next).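

In this assay, bromo in place of hydrogen on the phenyl, para to a large group, gives a 1.2-fold higher number from compound 1 to compound 4 (0.09 log units; within the scatter) and thus no step beyond the scatter. Among the compounds shown here, this is the only measured change on the phenyl rather than on the pyridinyl group at the carbonyl carbon, and it shows that this position carries a single bromine atom with the number staying within the scatter of compound 1. No available evidence bears on this result.

As far as these compounds go, whether an amine, a carboxylic acid or a methoxy group at the same position would give a step beyond the scatter remains open. Also open, from the compounds shown here alone, is whether the 4-bromophenyl group would behave the same way alongside the 5-bromopyridin-3-yl or 6-chloropyridin-3-yl group.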